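Swapping a bromophenyl limit for a methylphenyl analogue

The source may report more compounds than this note shows. Statements on the series, on what has been measured and on what is new or still open speak of the compounds shown alone.

Compound 1 `Fc1cccc(NC(=S)N/N=C/c2ccc3ccccc3n2)c1` gives 43800 nM in a functional assay on HL-60 cells (Homo sapiens) for antiproliferative activity, read by sulforhodamine B assay, with a stated time of 72 h; on this read-out lower numbers stand for stronger inhibition and higher numbers for weaker inhibition.
Compound 2 `COc1cccc(NC(=S)N/N=C/c2ccc3ccccc3n2)c1` gives 71200 nM.
Compound 3 `S=C(N/N=C/c1ccc2ccccc2n1)Nc1ccccc1Br` gives > 100000 nM, which is a limit of the assay and not a number.

Compound 3 therefore stands at the weak end of what has been measured, sitting at the limit (the limit of > 100000 nM in this assay, at which 1 of the 3 values shown sits). Compound 4 `Cc1cccc(NC(=S)N/N=C/c2ccc3ccccc3n2)c1` differs from it in one place: 3-methylphenyl in place of 2-bromophenyl on an amide-type nitrogen. The measured steps that bear on this change both run in the opposite direction, toward compound 3: an at least 2.2-fold higher number from compound 1 to compound 3 (0.35 log units; beyond the scatter) and an at least 1.4-fold higher number from compound 2 to compound 3 (0.14 log units; that floor lies within the scatter). Undoing a change of that kind, compound 4 is expected to come back down, a step of an at least 1.8-fold lower number from compound 3 to compound 4 (0.25 log units; that floor lies within the scatter), to a number close to what compound 1 gives with 43800 nM and what compound 2 gives with 71200 nM. Compound 4 is accordingly estimated at 55000 nM, with a range from 22000 nM to 140000 nM.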

Compound 4, half-maximal inhibitory concentration: > 100000 nM
Compound 4: only a limit was reported; the forecaster's own chance of this, stated with the estimate: 30%; middle value at least 1.8-fold (0.25 log units) away from the limit.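

In this assay compound 4 also gives only a limit and not a number, so 3-methylphenyl on the amide-type nitrogen stays at the same weak end as 2-bromophenyl: the limit of > 100000 nM in this assay, at which 2 of the 4 values shown sit. Methyl in place of fluoro gives an at least 2.2-fold higher number from compound 1 to compound 4 (0.35 log units; beyond the scatter) and methyl in place of methoxy gives an at least 1.4-fold higher number from compound 2 to compound 4 (0.14 log units; that floor lies within the scatter), so only the first step shows a clear loss. The step between compound 3 and compound 4 cannot be read.

As far as these compounds go, how far either compound lies past the limit remains open. So does whether an amine or a carboxylic acid in place of the methyl would return a measurable number.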